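This account rests on a few compounds, and the source may have more. Where it says the series, first, only, none or still open, it means among the compounds named here.

Measured compounds:
- compound 1, `CCCC[C@H](CCn1cncn1)c1ccc(Cl)cc1Cl`: 13.4 ug/mL
- compound 2, `CCCC[C@@H](CCn1cncn1)c1ccc(Cl)cc1Cl`: 6.5 ug/mL
- compound 3, `Clc1ccc([C@H](CCn2cncn2)Cc2ccccc2)cc1`: 25.7 ug/mL

In an ADME assay on HEp-2 cells (Homo sapiens) for cytotoxicity, read by MTT assay, with a stated time of 3 days (on this read-out lower numbers stand for higher toxicity in this test and higher numbers for lower toxicity in this test), compound 1 stands second highest of the three numbers; its nearest neighbour is compound 3, a gap within the scatter, and the furthest is compound 2, a gap beyond it. Among the measured compounds shown here, the one measured step, a 2.1-fold lower number from compound 1 to compound 2 (0.31 log units; beyond the scatter), rests on the fact that compounds 1 and 2 differ only in the configuration as drawn and says nothing about a change of substituent.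

Compound 4, `Clc1ccc([C@@H](CCn2cncn2)Cc2ccccc2)c(Cl)c1`, differs from compound 1 by phenyl in place of propyl on a saturated chain carbon, two bonds along the chain from an aromatic carbon. For the measured compounds named here, no measured step covers this exchange; compound 3, which also carries a benzyl on the chain carbon, gives 25.7 ug/mL, but no single-point step links it to compound 4. The expectation for compound 4 is therefore a step of a 1.1-fold higher number from compound 1 to compound 4 (0.05 log units; within the scatter) in this assay, not beyond the scatter in either direction. Compound 4 is estimated at 15 ug/mL, with a range from 6 ug/mL to 35 ug/mL.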

Compound 4, half-maximal cytotoxic concentration: 11.1 ug/mL
The estimate for compound 4 lay 1.4-fold (0.13 log units) above the measured number; low and high end bracket the measured number.
By their numbers in this assay, from the lowest: compounds 2, 4, 1 and 3 (each within the scatter of the next, the first and the last beyond it).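

Among the compounds shown here, the step, a 1.2-fold lower number from compound 1 to compound 4 (0.08 log units; within the scatter), is the first reading of a change at this position in this assay: phenyl in place of propyl on a saturated chain carbon, two bonds along the chain from an aromatic carbon, does not move the number beyond the scatter. Read in the wider cut, butyl to benzyl, the position therefore accepts a six-membered aromatic ring in place of an open chain without a readable change in this one pair. Nothing measured in this series gives a reason for this step.

For the compounds shown here, how configuration acts on the phenyl compounds stays open, as compound 1 and compound 2 are the only pair differing in configuration alone. Also open, as far as these compounds go, is whether an amine, a carboxylic acid or a longer chain in this place would stay within the scatter of compound 1.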